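The compounds below may be only part of what the source reports. "The series", "measured", "known", "first", "only" and "open" are said of these compounds alone.

Compound 2, drawn as `CC(C)C[C@H](NC(=O)[C@]1(Cc2ccccc2)CCN1C(=O)OCc1ccccc1)C(N)=O`, is tested in an ADME assay on HELF cells (Homo sapiens) for cytotoxicity, with a stated time of 3 days; a lower number here means that less compound is tolerated, a higher number that more compound is tolerated. In this assay compound 2 gives 100000 nM. Compound 1, drawn as `C[C@H](NC(=O)[C@]1(Cc2ccccc2)CCN1C(=O)OCc1ccc([N+](=O)[O-])cc1)C(N)=O`, gives 100000 nM in this assay, so compound 2 stands level with compound 1 at the digits shown, within the scatter. Compound 3, drawn as `CC(C)C[C@H](NC(=O)[C@@]1(Cc2ccccc2)CCN1C(=O)OCc1ccccc1)C(N)=O`, reaches only a limit of the assay, > 100000 nM in this assay. From the compounds shown here alone, the step of a number no lower from compound 2 to compound 3 (the limit leaves the size open) rests on (the fact that compounds 2 and 3 differ only in the configuration as drawn), and its size stays open because of the limit of > 100000 nM in this assay, at which 1 of the 3 values shown sits.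

Compound 4, drawn as `CC(C)[C@H](NC(=O)[C@]1(Cc2ccccc2)CCN1C(=O)OCc1ccccc1)C(N)=O`, differs from compound 2 by isopropyl in place of isobutyl on a saturated chain carbon bound to an amide-type nitrogen and a carbonyl carbon. Within the data shown here, no measured step bears on this change: the only step at hand concerns configuration alone and gives no readable size. With compound 1 and compound 2 at the same reading, no step beyond the scatter is expected for this change. Compound 4 is therefore expected to give 100000 nM in this assay, between 50000 nM and 200000 nM. The expected step of no change at the digits printed from compound 2 to compound 4 (within the scatter) lies within the scatter, with a fair chance that only a limit is reported.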

Compound 4, minimum cytotoxic concentration: > 100000 nM
Compound 4: only a limit was reported; the forecaster's own chance of this, stated with the estimate: 40%; the middle value sits exactly at the limit.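

Among the earlier compounds in this assay, the one step concerned configuration alone and said nothing about the group on this carbon. Among these compounds, the step of a number no lower from compound 2 to compound 4 (the limit leaves the size open) now adds a first change at this place, a saturated chain carbon bound to an amide-type nitrogen and a carbonyl carbon: with isopropyl in place of isobutyl, the number does not come down. How far it may have risen cannot be read, and the same holds for the step between the two configurations: the limit of > 100000 nM in this assay, at which 2 of the 4 values shown sit.

The compounds shown leave open whether this tolerance holds when the carbon carries a group of another kind, such as an amine, a carboxylic acid or a chain longer than isobutyl. They also leave open how far compound 4 and compound 3 actually lie from compound 2.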